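The compounds below may be only part of what the source reports. "The series", "measured", "known", "first", "only" and "open" are said of these compounds alone.

Measured compounds:
compound 1 `O=C(NOCc1ccccc1F)c1cn(-c2ccccc2)nc1-c1ccccc1` — 75700 nM
compound 2 `O=C(NOCc1ccccc1F)c1cn(-c2ccccc2)nc1-c1ccc(Cl)cc1` — 126000 nM
compound 3 `O=C(NOCc1ccccc1)c1cn(-c2ccccc2)nc1-c1ccc(F)cc1` — 217000 nM

In an ADME assay on HEK-293T cells (Homo sapiens) for antiproliferative activity, read by MTT assay, with a stated time of 48 h, in the presence of a further agent that is not named here (on this read-out lower numbers stand for higher toxicity in this test and higher numbers for lower toxicity in this test), compound 3 gives the highest of the three numbers; compound 2 lies within the scatter of it, compound 1 beyond. Compound 4 `O=C(NOCc1ccccc1F)c1cn(-c2ccccc2)nc1-c1ccc(F)cc1` arises from compound 3 by fluoro in place of hydrogen on an aromatic carbon. Within the data shown here, no measured step carries this change; the only measured step, a 1.7-fold higher number from compound 1 to compound 2 (0.22 log units; within the scatter), concerns a different ring and a different substituent, and it stayed within the scatter. Nothing here therefore points to a shift beyond the scatter, and the step from compound 3 to compound 4 is expected to be small, a 1.4-fold lower number from compound 3 to compound 4 (0.13 log units; within the scatter). Compound 4 is estimated at 160000 nM, with a range from 70000 nM to 350000 nM.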

Compound 4, half-maximal cytotoxic concentration: 147000 nM
The estimate for compound 4 lay 1.1-fold (0.04 log units) above the measured number, and the stated range covers the measured number.
By their numbers in this assay, from the lowest: compounds 1, 2, 4 and 3 (each within the scatter of the next, the first and the last beyond it).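

In this assay, fluoro in place of hydrogen on the benzyl group gives a 1.5-fold lower number from compound 3 to compound 4 (0.17 log units; within the scatter), so the change from benzyl to 2-fluorobenzyl now has a measured step, and that step stays within the scatter. With the 2-fluorobenzyl group held, fluoro on the other aromatic ring gives a 1.9-fold higher number from compound 1 to compound 4 (0.29 log units; within the scatter), and fluoro in place of chloro there gives a 1.2-fold higher number from compound 2 to compound 4 (0.07 log units; within the scatter), so neither step leaves the scatter. No evidence is available to explain these results.

The compounds shown leave open whether an amine or a carboxylic acid in place of this fluoro would give a step beyond the scatter. They also leave open whether a longer chain in place of the benzyl group would do so.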